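The compounds below may be only part of what the source reports. "The series", "measured", "known", "first", "only" and "open" are said of these compounds alone.

Measured so far:
compound 1 `O=C(COc1ccc2cc(/C=C3/SC(=O)NC3=O)ccc2c1)Nc1ccc(Br)cc1F` — 1900 nM in an assay on isolated protein for inhibition of histone deacetylase 4 (Homo sapiens), with a stated time of 1 h; on this read-out lower numbers stand for stronger inhibition and higher numbers for weaker inhibition
compound 2 `Cc1cccc(NC(=O)COc2ccc3cc(/C=C4/SC(=O)NC4=O)ccc3c2)n1` — 1100 nM in this assay

Compound 2 gives the lowest of the two numbers in this assay, but the step of a 1.7-fold lower number from compound 1 to compound 2 (0.24 log units; within the scatter) lies within the scatter, so the two compounds cannot be told apart. Compound 3 `O=C(COc1ccc2cc(/C=C3/SC(=O)NC3=O)ccc2c1)Nc1cc(Cl)cc(C(F)(F)F)c1` differs from compound 2 by 3-chloro-5-(trifluoromethyl)phenyl in place of 6-methylpyridin-2-yl on an amide-type nitrogen. Going by the values given here, only the step of a 1.7-fold lower number from compound 1 to compound 2 (0.24 log units; within the scatter) bears on this change: it exchanged an aryl on the same amide-type nitrogen and moved the number within the scatter. The same is expected here, with compound 3 estimated near compounds 1 and 2 rather than clearly apart from them. For compound 3 the expected step is a 1.4-fold higher number from compound 2 to compound 3 (0.13 log units; within the scatter), giving an estimate of 1500 nM with a range of 500 nM to 4500 nM in this assay.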

Compound 3, half-maximal inhibitory concentration: 4000 nM
The estimate for compound 3 lay 2.7-fold (0.43 log units) below the measured number, and the stated range covers the measured number.
By their numbers in this assay, from the lowest: compounds 2 and 1 (each within the scatter of the next); then compound 3.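

In this assay the aryl on the amide-type nitrogen proves not to be interchangeable: 3-chloro-5-(trifluoromethyl)phenyl gives a 3.6-fold higher number from compound 2 to compound 3 (0.56 log units; beyond the scatter) and a 2.1-fold higher number from compound 1 to compound 3 (0.32 log units; beyond the scatter) and both steps lie beyond the scatter. The earlier exchange of 4-bromo-2-fluorophenyl for 6-methylpyridin-2-yl did not show this, so the position can move the number, though only modestly among these three groups. No measurement here accounts for the shift.

As far as these compounds go, whether the rise follows the chlorine, the trifluoromethyl or both together stays open, as they occur only jointly. Also open, from the compounds shown here alone, is whether an amine or a carboxylic acid on this aryl would take the number clearly lower than that of compound 2.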